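The source may hold more compounds than are shown below. What is called first, only, known or untested is meant among the compounds shown, and "the series" means these compounds.

Measured compounds:
compound 1 `COc1ccc(F)c([C@H]2CC[C@H](COc3cccc([C@H](C4CC4)[C@H](C)C(=O)O)c3)CC2)c1` — 2 nM in a functional assay on cells for agonist activity at Free fatty acid receptor 1 (Homo sapiens), read by HTRF and inositol phosphate accumulation, with a stated time of 90 min; on this read-out lower numbers stand for an effect already at smaller amounts and higher numbers for an effect only at larger amounts of compound
compound 2 `COc1ccc(F)c([C@H]2CC[C@H](COc3cccc([C@H](C4CC4)[C@H](F)C(=O)O)c3)CC2)c1` — "not determined" (no result reported) in this assay

For the measured compounds named here, compound 1 gives 2 nM in this assay, the only number in the set. Compound 2 carries carboxy(fluoro)methyl where compound 1 carries the methyl-bearing acid group; for compound 2 the assay returned no result, so it stands on no number of its own and offers no anchor. Compound 3 `COc1ccc(F)c([C@H]2CC[C@H](COc3cccc([C@H](C4CC4)[C@](C)(F)C(=O)O)c3)CC2)c1` is the next member, not yet measured. It differs from compound 2 in one place: 1-carboxy-1-fluoroethyl in place of carboxy(fluoro)methyl on a saturated chain carbon bound to an aromatic carbon and a saturated ring carbon. Compound 3 thus holds both the methyl seen in compound 1 and the fluorine seen in compound 2 on the same saturated chain carbon. Going by the values given here, no measured pair shows the size of such a step, so the expectation rests on compound 1 alone: a small step in this assay, likely within the scatter or a modest loss. Compound 3 is estimated at 5 nM in this assay, with a range of 1 nM to 40 nM.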

Compound 3, half-maximal effective concentration: 89 nM
Compound 3: the middle estimate sits 18-fold (1.25 log units) below what was measured, and the stated range ends below it.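

In this assay, fluoro in place of hydrogen on a saturated chain carbon bound to a carbonyl carbon and two saturated chain carbons gives [ a 45-fold higher number from compound 1 to compound 3 (1.65 log units; beyond the scatter) ], a large step beyond the scatter. This position, already holding a methyl, therefore does not take this change without a clear loss on this read-out. Compound 2 has no number, so the step that adds the methyl to it cannot be read, and no measurement on hand gives a reason for the loss.

The compounds shown leave open whether the fluorine alone sets this result or only fluorine and methyl together on one carbon do. Also open, on these data alone, is whether a hydroxyl group or a second methyl in place of the fluorine would stay nearer to compound 1 at 2 nM.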